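Replacing the methoxyphenyl on the ring nitrogen: compound 4

A few compounds are considered here, and "the series" means these few. Any claim that something is new, unique, unknown or untested is made for them only; others in the source may bear on it.

Compound 1 `COc1cc2c(Oc3ccc(NC(=O)c4cn(-c5ccccc5OC)cn4)cc3F)ccnc2cc1OCCCN1CCN(C)CC1` — 80 nM
Compound 2 `COc1cc2c(Oc3ccc(NC(=O)c4cn(-c5ccc(Cl)cc5Cl)cn4)cc3F)ccnc2cc1OCCCN1CCN(C)CC1` — 3050 nM
Compound 3 `COc1cc2c(Oc3ccc(NC(=O)c4cn(-c5ccccc5OC)cn4)cc3F)ccnc2cc1OCCCN1CCCCC1` — 100 nM

Of the compounds shown here, three have been measured in a functional assay on HT-29 cells (Homo sapiens) for cytotoxicity, read by MTT assay, with a stated time of 72 h; a higher number here means a weaker inhibitor, a lower number a stronger inhibitor. Compound 3 gives 100 nM, the second highest of the three numbers; its nearest neighbour is compound 1 at 80 nM, a gap within the scatter, while compound 2 at 3050 nM lies far above. Compound 4 `COc1cc2c(Oc3ccc(NC(=O)c4cn(-c5cc(C)ccc5C)cn4)cc3F)ccnc2cc1OCCCN1CCCCC1` differs from compound 3 by 2,5-dimethylphenyl in place of 2-methoxyphenyl on an aromatic nitrogen. Within the data shown here, only one measured step touches the group on that nitrogen: a 38-fold higher number from compound 1 to compound 2 (1.58 log units; beyond the scatter), a large loss, whereas a 1.3-fold higher number from compound 1 to compound 3 (0.10 log units; within the scatter) shows that the chain-end change barely matters. A weakening is therefore expected, though the entering group is not the dichlorophenyl, so a smaller step is anticipated. Compound 4 is expected to give 400 nM, between 100 nM and 2500 nM. The expected step is a 4.0-fold higher number from compound 3 to compound 4 (0.60 log units; beyond the scatter).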

Compound 4, half-maximal inhibitory concentration: 580 nM
Compound 4: middle estimate off by 1.5-fold (0.16 log units), on the low side; the measured number falls inside the stated range.
By their numbers in this assay, from the lowest: compounds 1 and 3 (each within the scatter of the next); then compound 4; then compound 2.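

In this assay, the replacement of 2-methoxyphenyl on the ring nitrogen now also costs activity with the piperidin-1-yl chain end: a 5.8-fold higher number from compound 3 to compound 4 (0.76 log units; beyond the scatter). Together with a 38-fold higher number from compound 1 to compound 2 (1.58 log units; beyond the scatter), this shows that the loss is not confined to 2,4-dichlorophenyl, and both replacements have no hydrogen-bond acceptor in the group that enters. No measurement at hand gives a reason for the loss. The compounds shown leave open whether the methoxy oxygen itself matters, and how plain phenyl or 2-ethoxyphenyl on that nitrogen would compare.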